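Swapping the Aryl Group on the Amide Nitrogen

A few compounds are considered here, and "the series" means these few. Any claim that something is new, unique, unknown or untested is made for them only; others in the source may bear on it.

Three measured compounds share one core and differ only in the group on a saturated chain carbon bound to an aromatic nitrogen. Compound 1 `CCOC(=O)C1=Cc2ccccc2OC1(OCc1cn(CC(=O)NC2CCCCC2)nn1)C(F)(F)F` gives 9900 nM in a functional assay on A549 cells (Homo sapiens) for inhibition, read by MTT assay, with a stated time of 24 h; a lower number here means a stronger inhibitor, a higher number a weaker inhibitor. Compound 2 `CCCCCCCCn1cc(COC2(C(F)(F)F)Oc3ccccc3C=C2C(=O)OCC)nn1` reaches only > 150000 nM in this assay, which is a limit of the assay, not a number. Going by the values given here, compound 3 `CCOC(=O)C1=Cc2ccccc2OC1(OCc1cn(CC(=O)Nc2ccc(OC)cc2)nn1)C(F)(F)F` gives 29400 nM in this assay and so stands highest of the two numbers known. The step of a 3.0-fold higher number from compound 1 to compound 3 (0.47 log units; beyond the scatter), cyclohexyl to an aryl group on the amide-type nitrogen, was modest. Compound 4 `CCOC(=O)C1=Cc2ccccc2OC1(OCc1cn(CC(=O)Nc2ccccc2Br)nn1)C(F)(F)F` differs from compound 3 by 2-bromophenyl in place of 4-methoxyphenyl on an amide-type nitrogen, one aryl group for another on that same nitrogen. Because a 3.0-fold higher number from compound 1 to compound 3 (0.47 log units; beyond the scatter) was only modest, the expected step of a 1.2-fold lower number from compound 3 to compound 4 (0.07 log units; within the scatter) is small, in either direction, hardly beyond the scatter. Compound 4 is therefore estimated at 25000 nM, between 8000 nM and 80000 nM in this assay.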

Compound 4, half-maximal inhibitory concentration: > 150000 nM
Compound 4: only a limit was reported (the forecaster's own chance of this, stated with the estimate: 10%); at least 6.0-fold (0.77 log units) between middle value and limit.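

Earlier, changing the group on the amide-type nitrogen had shifted the number only modestly, yet replacing one aryl group with another here gives an at least 5.1-fold higher number from compound 3 to compound 4 (0.70 log units; beyond the scatter). Replacing cyclohexyl gives an at least 15-fold higher number from compound 1 to compound 4 (1.18 log units; beyond the scatter), so having an aryl group on this nitrogen does not alone set the result: which aryl group it is matters too. Compound 4 gives only a limit of this assay, not a number, and its step to compound 2 cannot be read: the limit of > 150000 nM in this assay, at which 2 of the 4 values shown sit.

As far as these compounds go, whether the change follows the bromine, its place in 2-bromophenyl or the loss of the methoxy group remains open. A plain phenyl or 4-bromophenyl group on this nitrogen would help separate these.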